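The source may hold more compounds than are shown below. What is called first, only, known or untested is meant among the compounds shown, and "the series" means these compounds.

In an ADME assay on THP-1 cells (Homo sapiens) for cytotoxicity, read by flow cytometry and propidium iodide staining, with a stated time of 72 h (on this read-out lower numbers stand for stronger inhibition and higher numbers for weaker inhibition), compound 1 (`COc1cccc(-c2oc3ccc(N)cc3c(=O)c2O)c1`) gives 2000 nM and stands level with compound 3 (`Nc1ccc2oc(-c3cccc(C(F)(F)F)c3)c(O)c(=O)c2c1`) at 2000 nM while compound 2 (`Nc1ccc2oc(-c3cccc(F)c3)c(O)c(=O)c2c1`) gives 30000 nM on the same read-out. The change to compound 4 (`COc1cccc(-c2oc3ccc(N)cc3c(=O)c2OC)c1`) is methyl in place of hydrogen on an oxygen on an aromatic ring so that hydroxy becomes methoxy. Within the data shown here, no measured step touches this hydroxy. The three known steps swap groups on an aromatic carbon and show only how far this series can move: a 15-fold higher number from compound 1 to compound 2 (1.18 log units; beyond the scatter) and a 15-fold lower number from compound 2 to compound 3 (1.18 log units; beyond the scatter) are large whereas no change at the digits printed from compound 1 to compound 3 (within the scatter) stays within the scatter. A moderate step in this assay is therefore expected, and an estimated 2.5-fold higher number from compound 1 to compound 4 (0.40 log units; beyond the scatter) is a tentative call on direction. For compound 4 the estimated value is 5000 nM with an expected range of 1200 nM to 25000 nM in this assay.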

Compound 4, half-maximal inhibitory concentration: 37000 nM
Estimate against measurement, compound 4: 7.4-fold (0.87 log units) below, and the stated range ends below it.
By their numbers in this assay, from the lowest: compounds 1 and 3 (each within the scatter of the next); then compounds 2 and 4 (each within the scatter of the next).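

In this assay, methyl in place of hydrogen on the oxygen turns hydroxy into methoxy and gives a 19-fold higher number from compound 1 to compound 4 (1.27 log units; beyond the scatter) as a large step. Among these compounds, this is the first measured change at this oxygen, and it shows that the hydroxy position is as sensitive as the aromatic carbon whose substituent swaps gave large steps. Nothing available here accounts for the step. An amine or an ethoxy at this place would show whether the hydrogen or the added carbon governs the rise. Going by these compounds, whether methoxy in place of hydroxy gives a similar step on compound 2 or compound 3 also stays open.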